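Oxolanyl versus methyl at the benzylic carbon of the shared core

A few compounds are considered here, and "the series" means these few. Any claim that something is new, unique, unknown or untested is made for them only; others in the source may bear on it.

Measured so far:
compound 1, `Cc1cc(C)c(CN2CCc3c(Cl)cc([C@@H](CO)[C@@H]4CCCO4)c(Cl)c3C2=O)c(=O)[nH]1`, 1220 nM
compound 2, `Cc1cc(C)c(CN2CCc3c(Cl)cc([C@H](C)CO)c(Cl)c3C2=O)c(=O)[nH]1`, 186 nM

Among the measured compounds shown here, in a functional assay on KARPAS-422 cells (Homo sapiens) for antiproliferative activity, read by resazurin assay, with a stated time of 72 h (on this read-out higher numbers stand for weaker inhibition and lower numbers for stronger inhibition), compound 2 stands at the lower of the two numbers; its only neighbour is compound 1, and the step of a 6.6-fold lower number from compound 1 to compound 2 (0.82 log units; beyond the scatter) lies beyond the scatter. Compound 3, `Cc1cc(C)c(CN2CCc3c(Cl)cc([C@H](CO)[C@H]4CCCO4)c(Cl)c3C2=O)c(=O)[nH]1`, is the next member. Relative to compound 2 the change is a group of 8 heavy atoms (6 carbon, 2 oxygen; one five-membered non-aromatic ring with 1 hetero atom) in place of a group of 4 heavy atoms (3 carbon, 1 oxygen; no ring), on an aromatic carbon. For the measured compounds named here, compound 3 shares its constitution with compound 1 and differs from it only in the configuration at both stereocentres, so the one step that bears on it is the one from compound 1 to compound 2, which went in the opposite direction. Reversing that change is expected to raise the number again, by a step of roughly the same size as a 6.6-fold lower number from compound 1 to compound 2 (0.82 log units; beyond the scatter), though the changed configuration leaves the size uncertain. For compound 3 the estimate is 800 nM (range 200 nM to 3000 nM), a step of a 4.3-fold higher number from compound 2 to compound 3 (0.63 log units; beyond the scatter).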

Compound 3, half-maximal inhibitory concentration: 63 nM
Compound 3: the middle estimate sits 13-fold (1.10 log units) above what was measured; the whole stated range lies above it.
By their numbers in this assay, from the lowest: compound 3; then compound 2; then compound 1.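

In this assay, the oxolan-2-yl group does not by itself raise the number at this position: a 3.0-fold lower number from compound 2 to compound 3 (0.47 log units; beyond the scatter), so in this configuration the larger group gives the lower number, the opposite of what the earlier comparison with methyl showed. The mirror-image pair gives a 19-fold lower number from compound 1 to compound 3 (1.29 log units; beyond the scatter), so the direction of the oxolan-2-yl versus methyl comparison depends on the configuration as drawn. That gap is a matter of stereochemistry alone, with the constitution unchanged: the fact that compounds 1 and 3 differ only in the configuration as drawn

Going by these compounds, both stereocentres invert together in this pair, so the share of each in the gap remains open. Also open, on these data alone, is how a carboxylic acid or an amine in place of the hydroxyl, or a six-membered oxane ring in place of the oxolan-2-yl group, would fare at this carbon.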